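The source may hold more compounds than are shown below. What is called first, only, known or untested is meant among the compounds shown, and "the series" means these compounds.

Compound 1 `CC[C@@H]1CC[C@@H](C(=O)N2CCN(C)CC2)N1C(=O)C1=C(C(C)C)N2C(=N[C@@](C)(c3ccc(Cl)cc3)[C@H]2c2ccc(Cl)cc2)S1`: 50%
Compound 2 `CC[C@@H]1CC[C@@H](C(=O)N2CCN(C)[C@H](C)C2)N1C(=O)C1=C(C(C)C)N2C(=N[C@@](C)(c3ccc(Cl)cc3)[C@H]2c2ccc(Cl)cc2)S1`: 76%

Among the compounds with values here, in an ADME assay on microsomes from liver (Mus musculus) for metabolic stability, read by LC-MS, with a stated time of 30 min, tested at 1 uM (a lower number here means that less of the compound is left, a higher number that more of the compound is left), compound 2 stands highest of the two measured compounds, with compound 1 the only neighbour. Within the data shown here, the one measured step is a number 26 percentage points higher from compound 1 to compound 2 (beyond the scatter). Compound 3 `CC[C@@H]1CC[C@@H](C(=O)N2CCN(C(C)=O)[C@@H](C)C2)N1C(=O)C1=C(C(C)C)N2C(=N[C@@](C)(c3ccc(Cl)cc3)[C@H]2c2ccc(Cl)cc2)S1` differs from compound 2 by a group of 10 heavy atoms (7 carbon, 2 nitrogen, 1 oxygen; one six-membered non-aromatic ring with 2 hetero atoms) in place of a group of 8 heavy atoms (6 carbon, 2 nitrogen; one six-membered non-aromatic ring with 2 hetero atoms), on a carbonyl carbon. Among the measured compounds shown here, no measured step concerns this kind of exchange on the carbonyl carbon, so the single step from compound 1 to compound 2 gives no direct guidance, and a step within the scatter is expected in this assay. Compound 3 is therefore estimated at 70% (range 45% to 92%), which would mean an expected step of a number 6 percentage points lower from compound 2 to compound 3 (within the scatter).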

Compound 3, percent of the compound remaining: 54%
For compound 3 the middle estimate is 16 percentage points above the measured one, within the range that was stated.
By their numbers in this assay, from the lowest: compounds 1 and 3 (each within the scatter of the next); then compound 2.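

In this assay, the exchange on the carbonyl carbon is not neutral: the step is a number 22 percentage points lower from compound 2 to compound 3 (beyond the scatter). The group entering in compound 3 is also a six-membered ring with two hetero atoms, so a change of this kind at this place can outweigh the earlier gain. The result lands level with the unmethylated ring, at a number 4 percentage points higher from compound 1 to compound 3 (within the scatter). Nothing measured here explains this result. Open, from the compounds shown here alone, is how a morpholine or a piperidine on the same carbonyl carbon would compare.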